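A few compounds are considered here, and "the series" means these few. Any claim that something is new, unique, unknown or untested is made for them only; others in the source may bear on it.

Measured so far in an assay on isolated protein for inhibition of protein deacetylase HDAC6 (Homo sapiens), tested at 0.5 uM; a lower number here means less inhibition, a higher number more inhibition at the concentration tested (going by the name of the read-out):

compound 1, `O=C(NO)c1ccc(-c2nc(N3CCCC3)c3ccccc3n2)cc1`: 57.2%
compound 2, `O=C(NO)c1ccc(-c2nc(N3CCC(F)(F)CC3)c3ccccc3n2)cc1`: 71.7%

Compound 1 stands lowest of the two numbers; its nearest neighbour is compound 2, reached by a number 14.5 percentage points higher from compound 1 to compound 2 (beyond the scatter). Compound 3, `O=C(NO)c1ccc(-c2nc(N3CCCC3)c3ccc(Cl)cc3n2)cc1`, differs from compound 1 by chloro in place of hydrogen on an aromatic carbon, on the six-membered aromatic ring of carbon only within the fused system. Within the data shown here, the one measured step, from compound 1 to compound 2, alters a different place and so gives no direct guide; nothing measured speaks to a chloro at this site. The expected step is therefore a number 0.8 percentage points higher from compound 1 to compound 3 (within the scatter), within the scatter. Compound 3 is estimated at 58%, in the range 40% to 76%.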

Compound 3, a percentage reported as inhibition, at one concentration (the size of the read-out at that concentration, not a potency): 54.6%
Compound 3: the middle estimate sits 3.4 percentage points above what was measured, and the stated range covers the measured number.
By their numbers in this assay, from the lowest: compounds 3 and 1 (each within the scatter of the next); then compound 2.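

In this assay, among these compounds, chloro in place of hydrogen on this aromatic carbon gives a number 2.6 percentage points lower from compound 1 to compound 3 (within the scatter), the first reading at this position of the shared core. On the core of compound 1, this site therefore accepts one chlorine atom with no change beyond the scatter. Nothing available explains this result.

From the compounds shown here alone, whether a methoxy group or an amine at the same carbon would also stay within the scatter of compound 1 remains open. So does the outcome of chloro on the core of compound 2, which carries 4,4-difluoropiperidin-1-yl.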